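Bromo in place of methyl: notes on compound 3

A few compounds are considered here, and "the series" means these few. Any claim that something is new, unique, unknown or untested is made for them only; others in the source may bear on it.

In a functional assay on HL-60 cells (Homo sapiens) for cytotoxicity, read by MTT assay, with a stated time of 46 h (on this read-out lower numbers stand for stronger inhibition and higher numbers for weaker inhibition), compound 1 `O=C1/C(=C/c2ccccc2)C(c2ccccc2)Oc2ccccc21` gives 33300 nM, and compound 2 `Cc1ccc(/C=C2/C(=O)c3ccccc3OC2c2ccccc2)cc1` gives 40900 nM. Among the compounds with values here, these two values lie within the scatter of each other, so compound 2 stands level with its only measured neighbour.

Compound 3 `O=C1/C(=C/c2ccc(Br)cc2)C(c2ccccc2)Oc2ccccc21` has not yet been measured. Its difference from compound 2 is bromo in place of methyl on an aromatic carbon, para to a large group, or 4-methylphenyl to 4-bromophenyl.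

Within the data shown here, only one measured step bears on this change: a 1.2-fold higher number from compound 1 to compound 2 (0.09 log units; within the scatter), which is methyl in place of hydrogen on an aromatic carbon. Among the measured compounds shown here, no measured compound carries bromo, so this step is only an indirect guide. No step beyond the scatter is expected in this assay, and no direction is clearly favoured.

The expected change is a 1.2-fold lower number from compound 2 to compound 3 (0.07 log units; within the scatter).

For compound 3 the estimated value is 35000 nM, with an expected range of 16000 nM to 70000 nM.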

Compound 3, half-maximal inhibitory concentration: 5700 nM
The estimate for compound 3 lay 6.1-fold (0.79 log units) above the measured number; the whole stated range lies above it.
By their numbers in this assay, from the lowest: compound 3; then compounds 1 and 2 (each within the scatter of the next).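

In this assay, the 4-bromophenyl group stands apart from both neighbours at this place on the ring: bromo in place of methyl gives a 7.2-fold lower number from compound 2 to compound 3 (0.86 log units; beyond the scatter) and bromo in place of hydrogen gives a 5.8-fold lower number from compound 1 to compound 3 (0.77 log units; beyond the scatter) on the same core. The earlier step, a 1.2-fold higher number from compound 1 to compound 2 (0.09 log units; within the scatter) with methyl in place of hydrogen, had left the number within the scatter, so this position is now seen to respond to at least one substituent, and among the three compounds the response goes with bromo and not with methyl. Nothing at hand accounts for the difference between bromo and methyl at this position.

From the compounds shown here alone, it remains open whether the lower number is particular to bromo or is shared by other groups on the same aromatic carbon, such as chloro, methoxy, an amine or a carboxylic acid. Going by these compounds, it is also open whether bromo would give a step of similar size on the other phenyl ring of the core, or in any read-out other than this assay on which these compounds could be compared.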